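A few compounds are considered here, and "the series" means these few. Any claim that something is new, unique, unknown or untested is made for them only; others in the source may bear on it.

In a functional assay (Nicotiana tabacum) (on this read-out higher numbers stand for weaker inhibition and lower numbers for stronger inhibition), three compounds on one shared core differ only in the straight chain on the nitrogen. Compound 1 `CCCCNc1nc(SC)nc2ncccc12`, with butyl, gives 270 nM. Compound 2 `CCCCCNc1nc(SC)nc2ncccc12`, with pentyl, gives 650 nM. Compound 3 `CCCCCCNc1nc(SC)nc2ncccc12`, with hexyl, gives 3330 nM, the highest number and so the weakest inhibition of the three.

The next structure is compound 4 `CSc1nc(NC2CCC2)c2cccnc2n1`, and the change is cyclobutyl in place of hexyl on a nitrogen on an aromatic ring. Among the compounds with values here, three measured steps bear on it, all in the chain at that nitrogen. They are a 2.4-fold higher number from compound 1 to compound 2 (0.38 log units; beyond the scatter), a 5.1-fold higher number from compound 2 to compound 3 (0.71 log units; beyond the scatter) and, over the whole series, a 12-fold higher number from compound 1 to compound 3 (1.09 log units; beyond the scatter). Across these three compounds, each longer chain gave a higher number, and no compound goes against this. None of them carries a ring at this place, so the data do not show how a ring compares with an open chain.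

A large step towards lower numbers is therefore expected in this assay, somewhat smaller than the span from hexyl back to butyl. The expected change is a 6.1-fold lower number from compound 3 to compound 4 (0.78 log units; beyond the scatter). Compound 4 is estimated at 550 nM, with an expected range from 150 nM to 2000 nM.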

Compound 4, half-maximal inhibitory concentration: 720 nM
The estimate for compound 4 lay 1.3-fold (0.12 log units) below the measured number, and the stated range covers the measured number.
By their numbers in this assay, from the lowest: compound 1; then compounds 2 and 4 (each within the scatter of the next); then compound 3.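

In this assay, within the data shown here, cyclobutyl is the first ring at this nitrogen, and it brings a 4.6-fold lower number from compound 3 to compound 4 (0.67 log units; beyond the scatter) in place of hexyl, so a ring here does not carry the full cost seen with the longest open chain. Set against the shorter chains, the picture is more limited: a 1.1-fold higher number from compound 2 to compound 4 (0.04 log units; within the scatter) means that cyclobutyl and pentyl cannot be told apart on this read-out, while a 2.7-fold higher number from compound 1 to compound 4 (0.43 log units; beyond the scatter) shows that cyclobutyl does not reach the low number given by butyl. No supporting information is available to explain where the ring falls among the open chains.

The compounds shown leave open whether ring size matters at this nitrogen, since cyclopropyl, cyclopentyl and cyclohexyl would each be needed to show whether cyclobutyl is a favourable or an unfavourable ring. They also leave open whether the trend among the open chains continues below butyl, as propyl or ethyl would test, and whether a branched chain such as isobutyl, or a ring holding an oxygen such as oxetanyl, would give a lower number than butyl.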